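Cytotoxicity notes: compound 1 to compound 4

A few compounds are considered here, and "the series" means these few. Any claim that something is new, unique, unknown or untested is made for them only; others in the source may bear on it.

Compound 1 `O=C(c1ccc2c(c1)OCCO2)C1CCN(Cc2coc(-c3ccc(F)cc3)n2)CC1` was tested in an ADME assay on HEK293 cells (Homo sapiens) for cytotoxicity, read by MTT assay, with a stated time of 36 h; a lower number here means a stronger inhibitor, a higher number a weaker inhibitor. In this assay compound 1 gives only a limit of > 150 ug/mL. Compound 2 `O=C(c1ccc2c(c1)OCCO2)C1CCN(Cc2coc(-c3ccc(Cl)cc3)n2)CC1` differs from it by chloro in place of fluoro on an aromatic carbon; in this assay compound 2 likewise reaches only a limit of > 150 ug/mL. Compound 3 `O=C(c1ccc2c(c1)OCCO2)C1CCN(Cc2coc(-c3ccc(F)c(F)c3)n2)CC1` carries fluoro in place of hydrogen on an aromatic carbon; in this assay compound 3 also stops at a limit of > 150 ug/mL. The three steps among them, a step that the two limits leave unreadable from compound 1 to compound 2, a step that the two limits leave unreadable from compound 1 to compound 3 and a step that the two limits leave unreadable from compound 2 to compound 3, therefore have no readable size, and all three values sit at the same point, (the limit of > 150 ug/mL in this assay, at which 3 of the 3 values shown sit).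

Compound 4 `COc1ccc(C(=O)C2CCN(Cc3coc(-c4ccc(F)cc4)n3)CC2)cc1` is the next member, not yet measured. It differs from compound 1 by 4-methoxyphenyl in place of 2,3-dihydro-1,4-benzodioxin-6-yl on a carbonyl carbon. For the measured compounds named here, none of the measured steps touches the carbonyl side of the shared core; they all vary the aryl on the other end and are unreadable in any case, so they give no direction for the change at the ketone. With every measured member of the series at the limit, compound 4 is expected to show no step beyond the scatter, a step that the limit leaves unreadable from compound 1 to compound 4, and most likely to return a limit as well. Compound 4 is thus estimated at 200 ug/mL, within 100 ug/mL to 400 ug/mL.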

Compound 4, half-maximal inhibitory concentration: > 150 ug/mL
Compound 4: no number, only a limit (the forecaster's own chance of this, stated with the estimate: 85%); the middle value is on the limit's open side.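

In this assay compound 4 gives > 150 ug/mL as a limit only. No size can be read for the step between compound 1 and compound 4, and all the values shown sit at one point: the limit of > 150 ug/mL in this assay, at which 4 of the 4 values shown sit. The compounds shown leave open whether any change at either end of the shared core would give a readable number in this assay rather than a limit.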